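A few compounds are considered here, and "the series" means these few. Any claim that something is new, unique, unknown or untested is made for them only; others in the source may bear on it.

Measured so far in an assay on Huh-7 cells for agonist activity at Bile acid receptor (Homo sapiens), read by a luciferase reporter; on this read-out higher numbers stand for an effect only at larger amounts of compound and lower numbers for an effect already at smaller amounts:
- compound 1 `CC(C)c1onc(-c2c(Cl)cccc2Cl)c1COc1ccc(-c2nc3ccc(C(=O)O)cc3n2C2CCC2)cc1`: 14.4 nM
- compound 2 `CC(C)c1onc(-c2c(Cl)cccc2Cl)c1COc1ccc(-c2nc3ccc(C(=O)O)cc3n2C2CCCC2)cc1`: 13.6 nM
- compound 3 `CC(=O)C1CCC(Cn2c(-c3ccc(OCc4c(-c5c(Cl)cccc5Cl)noc4C(C)C)cc3)nc3ccc(C(=O)O)cc32)CC1`: 1170 nM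

Compound 3 stands highest of the three numbers in this assay. The two steps leading to it, an 81-fold higher number from compound 1 to compound 3 (1.91 log units; beyond the scatter) and an 86-fold higher number from compound 2 to compound 3 (1.93 log units; beyond the scatter), are large and beyond the scatter, whereas a 1.1-fold lower number from compound 1 to compound 2 (0.02 log units; within the scatter) lies within it.

Compound 4 `CCCC(CCC)n1c(-c2ccc(OCc3c(-c4c(Cl)cccc4Cl)noc3C(C)C)cc2)nc2ccc(C(=O)O)cc21` follows from compound 3 by 1-propylbutyl in place of (4-acetylcyclohexyl)methyl on an aromatic nitrogen. Within the data shown here, both large steps above bear on this change, as each replaces a small cycloalkyl with the (4-acetylcyclohexyl)methyl group; the new 1-propylbutyl group has no measured counterpart here. A marked fall in this assay is therefore expected, though not necessarily back to the level of compound 1. Compound 4 is expected near 50 nM, with a range of 10 nM to 300 nM. The expected step is a 23-fold lower number from compound 3 to compound 4 (1.37 log units; beyond the scatter).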

Compound 4, half-maximal effective concentration: 1.8 nM
Compound 4: middle estimate off by 28-fold (1.44 log units), on the high side; the whole stated range lies above it.
By their numbers in this assay, from the lowest: compound 4; then compounds 2 and 1 (each within the scatter of the next); then compound 3.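

Working notes: in this assay the open-chain 1-propylbutyl group on the aromatic nitrogen goes beyond both small cycloalkyl groups, with an 8.0-fold lower number from compound 1 to compound 4 (0.90 log units; beyond the scatter) and a 7.6-fold lower number from compound 2 to compound 4 (0.88 log units; beyond the scatter). Set against (4-acetylcyclohexyl)methyl, the same change gives a 650-fold lower number from compound 3 to compound 4 (2.81 log units; beyond the scatter), so among these four compounds a ring on this nitrogen is not needed for the lowest number. Nothing measured here gives a reason for these steps.

On these data alone, whether an unbranched pentyl chain or a 1-ethylpropyl group on this nitrogen would hold the low number stays open. So does whether a hydroxyl or an amine on the 1-propylbutyl chain would be accepted.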